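This account rests on a few compounds, and the source may have more. Where it says the series, first, only, none or still open, it means among the compounds named here.

Measured in a functional assay on A549 cells (Homo sapiens) for inhibition, read by MTT assay, with a stated time of 72 h; a higher number here means a weaker inhibitor, a lower number a stronger inhibitor:
- Compound 1 `Nc1ncnc2c1c(-c1cnc3[nH]ccc3c1)nn2CCCCCCCCC(=O)NO`: 12300 nM
- Compound 2 `Nc1ncnc2c1c(-c1cnc3[nH]ccc3c1)nn2CCCCCC(=O)NO`: > 150000 nM (a limit)
- Compound 3 `Nc1nc2cc(-c3nn(CCC(=O)NO)c4ncnc(N)c34)ccc2o1`: > 150000 nM (a limit)

Compound 3 has no number, only the limit > 150000 nM. It is among the compounds at the limit of > 150000 nM in this assay, at which 2 of the 3 values shown sit.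

Compound 4 `Nc1nc2cc(-c3nn(CC(=O)NO)c4ncnc(N)c34)ccc2o1` differs from it by hydroxycarbamoyl in place of (hydroxycarbamoyl)methyl on a saturated chain carbon bound to an aromatic nitrogen. Among the compounds with values here, the one measured step that bears on this also shortens a chain, though a longer one on a different core: an at least 12-fold higher number from compound 1 to compound 2 (1.08 log units; beyond the scatter). That step was large and led towards weaker inhibition. In this assay, no gain is therefore expected, and any further loss would be in the same direction. The expected step is a step that the limit leaves unreadable from compound 3 to compound 4. Compound 4 is estimated at 200000 nM, with an expected range of 100000 nM to 400000 nM, and will most likely be reported only as a limit.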

Compound 4, half-maximal inhibitory concentration: 27700 nM
For compound 4 the middle estimate is 7.2-fold (0.86 log units) above the measured one; measured number below the stated range.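

In this assay, cutting 2-(hydroxycarbamoyl)ethyl to (hydroxycarbamoyl)methyl gives an at least 5.4-fold lower number from compound 3 to compound 4 (0.73 log units; beyond the scatter), so on this core the shorter chain goes with stronger inhibition. This runs opposite to the shortening on the core of compound 1, which gave an at least 12-fold higher number from compound 1 to compound 2 (1.08 log units; beyond the scatter), so chain shortening has no single direction across the two cores. The true size of the new step stays unknown, because compound 3 carries only a limit: the limit of > 150000 nM in this assay, at which 2 of the 4 values shown sit.

As far as these compounds go, whether a carboxylic acid in place of hydroxycarbamoyl would keep the inhibition of compound 4 remains open. So does the effect of a longer chain on this core.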